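The source may hold more compounds than are shown below. What is called first, only, known or untested is meant among the compounds shown, and "the series" means these compounds.

In an ADME assay on A549 cells (Homo sapiens) for cytotoxicity, read by resazurin assay, with a stated time of 48 h (a higher number here means that more compound is tolerated, a lower number that less compound is tolerated), three relatives sharing one core have been examined: compound 1 `CC(=O)Nc1ccc(NC(=O)c2cc(Cl)ccc2O)c(Cl)c1`, compound 2 `CCCNc1ccc(NC(=O)c2cc(Cl)ccc2O)c(Cl)c1` and compound 3 `O=C(Nc1ccc(N(CC2CC2)CC2CC2)cc1Cl)c1cc(Cl)ccc1O`. For compound 1 the result is "not determined" (no result reported). Compound 2 gives 22500 nM. Compound 3 gives 12800 nM, which lies within the usual scatter of compound 2. Compound 4 `O=C(Nc1ccc(NCc2ccc(Br)cc2)cc1Cl)c1cc(Cl)ccc1O` carries (4-bromobenzyl)amino in place of bis(cyclopropylmethyl)amino on an aromatic carbon. Among the measured compounds shown here, one measured step bears on this, a 1.8-fold lower number from compound 2 to compound 3 (0.24 log units; within the scatter), and it also exchanged the group on that carbon while staying within the scatter. For the measured compounds named here, no measured compound carries the incoming group, so the range must stay wide. The expected step in this assay is therefore modest, an estimated 1.3-fold lower number from compound 3 to compound 4 (0.11 log units; within the scatter). For compound 4 the estimate is 10000 nM, with an expected range of 3500 nM to 28000 nM.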

Compound 4, half-maximal cytotoxic concentration: 40900 nM
Estimate against measurement, compound 4: 4.1-fold (0.61 log units) below, and the stated range ends below it.
By their numbers in this assay, from the lowest: compounds 3, 2 and 4 (each within the scatter of the next, the first and the last beyond it).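

In this assay, this position now shows a change that clears the usual scatter: (4-bromobenzyl)amino in place of bis(cyclopropylmethyl)amino gives a 3.2-fold higher number from compound 3 to compound 4 (0.50 log units; beyond the scatter). The second comparison, a 1.8-fold higher number from compound 2 to compound 4 (0.26 log units; within the scatter), stays within the scatter, so 4-bromophenyl in place of ethyl on the chain cannot be told apart from no change. Nothing available gives a reason for the step from the two-cyclopropylmethyl amine. Going by these compounds, it remains open whether an unsubstituted amine, or a benzyl group with a carboxylic acid in place of the bromine, would be tolerated similarly.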